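Swapping fluoro for acetoxy on a short side chain

The compounds below may be only part of what the source reports. "The series", "measured", "known", "first", "only" and "open" are said of these compounds alone.

Compound 1 `COc1nc(C)c(CCO)c(OC)n1` in a functional assay on NCI-H460 cells (Homo sapiens) for antiproliferative activity, read by MTT assay, with a stated time of 24 h (a lower number here means a stronger inhibitor, a higher number a weaker inhibitor), gives a limit of > 100000 nM.
Compound 2 `COc1nc(C)c(CCF)c(OC)n1` in this assay gives a limit of > 100000 nM.

Compound 2 therefore stands at the limit of > 100000 nM in this assay, at which 2 of the 2 values shown sit, and no number is known for it. Going by the values given here, the one measured step, a step that the two limits leave unreadable from compound 1 to compound 2, is not readable because the limit of > 100000 nM in this assay, at which 2 of the 2 values shown sit, hides both ends. Compound 3 `COc1nc(C)c(CCOC(C)=O)c(OC)n1` differs from compound 2 by acetoxy in place of fluoro on a saturated chain carbon, two bonds along the chain from an aromatic carbon. Nothing measured shows whether such a change moves potency, so compound 3 is expected to stay near the limit, with a step that the limit leaves unreadable from compound 2 to compound 3. The estimate for compound 3 in this assay is 150000 nM, ranging from 40000 nM to 600000 nM.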

Compound 3, half-maximal inhibitory concentration: 47000 nM
Beside the measured number, compound 3's estimate is 3.2-fold (0.50 log units) above it, and the stated range covers the measured number.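

Going by these compounds alone, compound 3 is the first here to give a number rather than a limit, so a change at this position can now be read. In this assay, acetoxy in place of fluoro gives an at least 2.1-fold lower number from compound 2 to compound 3 (0.32 log units; beyond the scatter), and acetyl in place of hydrogen on the oxygen gives an at least 2.1-fold lower number from compound 1 to compound 3 (0.32 log units; beyond the scatter). The full size of both steps stays hidden, because each starts from a limit: the limit of > 100000 nM in this assay, at which 2 of the 3 values shown sit.

The compounds shown leave open whether acetoxy is special at this position. From the compounds shown here alone, how an amine or a longer chain in its place would read in this assay also remains open.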